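Series notes: aryl and amine changes at the chain terminus

The compounds below may be only part of what the source reports. "The series", "measured", "known", "first", "only" and "open" are said of these compounds alone.

Three sulfonamides carry the same bis(trifluoromethyl)phenyl core. In a functional assay on BXPC-3 cells (Homo sapiens) for inhibition, read by MTT assay, with a stated time of 72 h (a lower number here means a stronger inhibitor of growth, a higher number a weaker inhibitor of growth), compound 1 `O=S(=O)(NCCNCc1cccc2ccccc12)c1cc(C(F)(F)F)cc(C(F)(F)F)c1` gives 23000 nM, compound 3 `CC(C)(C)c1ccc(CNCCNS(=O)(=O)c2cc(C(F)(F)F)cc(C(F)(F)F)c2)cc1` gives 8800 nM, and compound 2 `CN(CCCNS(=O)(=O)c1cc(C(F)(F)F)cc(C(F)(F)F)c1)Cc1ccccc1` gives 39000 nM. The number of compound 2 lies within the scatter of that of compound 1 and is beyond the scatter from that of compound 3. Going by the values given here, the one step between measured compounds, a 2.6-fold lower number from compound 1 to compound 3 (0.42 log units; beyond the scatter), concerns the aryl group on the amine carbon alone.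

Compound 4 `COc1ccccc1CNCCCNS(=O)(=O)c1cc(C(F)(F)F)cc(C(F)(F)F)c1` differs from compound 2 in (2-methoxybenzyl)amino in place of benzyl(methyl)amino on a saturated chain carbon, three bonds along the chain from a sulfonamide nitrogen. This change alters both the aryl group and the substitution at the amine nitrogen; only the aryl part has any precedent, and that precedent was a modest shift. Among the compounds with values here, no measured step addresses the loss of the methyl on the amine nitrogen. A step no larger than the scatter, or a modest lowering, is therefore expected in this assay. Compound 4 is estimated at 22000 nM, within 8000 nM to 55000 nM. The expected step of a 1.8-fold lower number from compound 2 to compound 4 (0.25 log units; within the scatter) stays within the scatter.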

Compound 4, concentration for 50% growth inhibition: 1700 nM
Estimate against measurement, compound 4: 13-fold (1.11 log units) above; the measured number lies below the stated range.
By their numbers in this assay, from the lowest: compound 4; then compound 3; then compounds 1 and 2 (each within the scatter of the next).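

In this assay, going by these compounds alone, the only earlier step of a 2.6-fold lower number from compound 1 to compound 3 (0.42 log units; beyond the scatter) changed the aryl group alone and stayed modest, whereas (2-methoxybenzyl)amino in place of benzyl(methyl)amino gives a 23-fold lower number from compound 2 to compound 4 (1.36 log units; beyond the scatter) and is a large step. The chain terminus is therefore a place where one exchange can move the number strongly, and the secondary amine with its 2-methoxybenzyl group is the change that does so here. No evidence at hand accounts for the size of this step.

Compound 4 combines the methoxy group with the loss of the methyl on the amine nitrogen, and the compounds shown do not separate the two; a plain benzylamino or a (2-methoxybenzyl)(methyl)amino group on the same chain would. On these data alone, whether an ethoxy group or a fluorine in place of the methoxy keeps the step also stays open.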